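This account rests on a few compounds, and the source may have more. Where it says the series, first, only, none or still open, it means among the compounds named here.

Measured so far in a functional assay on HepG2 cells (Homo sapiens) for cytotoxicity, read by MTT assay, with a stated time of 72 h; on this read-out lower numbers stand for stronger inhibition and higher numbers for weaker inhibition: compound 1 `CNC(=O)c1cc(Oc2ccc(C(=O)/C=C/c3cc(OC)c(OC)c(OC)c3)cc2)ccn1` with 560 nM; compound 2 `CNC(=O)c1cc(Oc2ccc(C(=O)/C=C/c3ccc(Cl)cc3Cl)cc2)ccn1` with 11700 nM.

Compound 2 gives the highest of the two numbers in this assay, and the gap to compound 1 lies beyond the usual scatter. Compound 3 `CNC(=O)c1cc(Oc2ccc(C(=O)/C=C/c3ccc(Br)cc3)cc2)ccn1` differs from compound 2 by 4-bromophenyl in place of 2,4-dichlorophenyl on a double-bonded chain carbon bound to a double-bonded chain carbon. Within the data shown here, no measured pair covers this change, so the expectation rests on the two values alone. A small step is expected, a 1.5-fold lower number from compound 2 to compound 3 (0.17 log units; within the scatter), toward a lower number or none beyond the scatter. Compound 3 is estimated to give about 8000 nM in this assay, within a range from 2500 nM to 25000 nM.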

Compound 3, half-maximal inhibitory concentration: > 50000 nM
Compound 3 was reported as a limit (the forecaster's own chance of this, stated with the estimate: 5%); middle value at least 6.2-fold (0.79 log units) from the limit.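

In this assay, the place on a double-bonded chain carbon bound to a double-bonded chain carbon responds to a change of halogen-bearing phenyl group alone: 4-bromophenyl in place of 2,4-dichlorophenyl gives an at least 4.2-fold higher number from compound 2 to compound 3 (0.63 log units; beyond the scatter). This is the only step shown between compounds that differ in one place. Compound 3 stands as a limit, not a number: the limit of > 50000 nM in this assay, at which 1 of the 3 values shown sits.

The compounds shown leave open whether the step follows the bromine itself or the loss of the two chlorines. They also leave open how 4-chlorophenyl or an aminophenyl group would read at this place.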